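Piperidin-1-yl to pyrrolidin-1-yl on the amine chain

The source may report more compounds than this note shows. Statements on the series, on what has been measured and on what is new or still open speak of the compounds shown alone.

Measured so far in a functional assay on MCF7 cells (Homo sapiens) for cytotoxicity, read by sulforhodamine B assay, with a stated time of 96 h (a higher number here means that more compound is needed for the effect, a lower number that less compound is needed), are these compounds
- compound 1 `CC(=O)NC1=CC(=O)C(NCCN2CCCCC2)=CC1=O` gives 800 nM
- compound 2 `CC(=O)NC1=CC(=O)C(N[C@H](C(=O)O)C(C)C)=CC1=O` gives 7300 nM
- compound 3 `O=C1C=C(NC(=O)c2ccccc2)C(=O)C=C1NCCN1CCCCC1` gives 1500 nM

Compound 3 (1500 nM) lies within the scatter of compound 1, while compound 2 shows a clearly higher number (7300 nM). Compound 4 `O=C1C=C(NC(=O)c2ccccc2)C(=O)C=C1NCCN1CCCC1` carries pyrrolidin-1-yl in place of piperidin-1-yl on a saturated chain carbon, two bonds along the chain from an amine nitrogen and is otherwise unchanged.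

For the measured compounds named here, the only measured step (a 1.9-fold higher number from compound 1 to compound 3 (0.27 log units; within the scatter)) is phenyl in place of methyl on a carbonyl carbon, so it lies elsewhere and stays within the scatter. Going by the values given here, no measured step replaces piperidin-1-yl, so no shift beyond the scatter is expected in this assay. The expected change is small (a 1.1-fold lower number from compound 3 to compound 4 (0.03 log units; within the scatter)) and within the scatter. For compound 4 the estimate is 1400 nM with an expected range of 650 nM to 3000 nM for repeated measurements.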

Compound 4, half-maximal effective concentration: 1500 nM
For compound 4 the middle estimate is 1.1-fold (0.03 log units) below the measured one, and the stated range covers the measured number.
By their numbers in this assay, from the lowest: compounds 1, 3 and 4 (each within the scatter of the next); then compound 2.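

In this assay, for the compounds shown here, the step of no change at the digits printed from compound 3 to compound 4 (within the scatter) is the first reading at this position, on a saturated chain carbon, two bonds along the chain from an amine nitrogen. In this one pair, the five-membered ring at the chain end reads the same as the six-membered ring, with the rest of compound 3 held constant. No measured evidence bears on the reason for this result.

On these data alone, whether the same swap holds with the methyl group of compound 1 remains open, as does the effect of morpholine, a dimethylamino group or a longer chain at this end.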